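The source may report more compounds than this note shows. Statements on the series, on what has been measured and on what is new or still open speak of the compounds shown alone.

Measured compounds in a functional assay on HepG2 cells (Homo sapiens) for antiproliferative activity, read by XTT assay, with a stated time of 72 h; a lower number here means a stronger inhibitor, a higher number a weaker inhibitor:

compound 1, `Cc1ncnc2c1c(I)cn2[C@@H]1O[C@H](CO)[C@@H](O)[C@H]1O`: compound 1 gives 3460 nM
compound 2, `C#Cc1cn([C@@H]2O[C@H](CO)[C@@H](O)[C@H]2O)c2ncnc(C)c12`: compound 2 gives 290 nM
compound 3, `C#Cc1cn([C@@H]2O[C@H](CO)[C@@H](O)[C@H]2O)c2nc(C)nc(N)c12`: for compound 3 only a limit is reported, > 20000 nM

Compounds 1 and 2 share one core and differ at a single point. The change is iodo in place of ethynyl on an aromatic carbon. Its effect is a 12-fold higher number from compound 2 to compound 1 (1.08 log units; beyond the scatter), a loss in this assay that lies beyond the scatter.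

Compound 3 carries a second core; the difference between the two cores is not broken down here. Its value is a limit of the assay, not a number, as noted in the limit of > 20000 nM in this assay, at which 1 of the 3 values shown sits.

Compound 4, `Cc1nc(N)c2c(I)cn([C@@H]3O[C@H](CO)[C@@H](O)[C@H]3O)c2n1`, has not been measured in this assay. It stands to compound 3 as compound 1 stands to compound 2: the change is iodo in place of ethynyl on an aromatic carbon, the same change as in the measured pair, made on the core of compound 3.

The expected step is a step that the limit leaves unreadable from compound 3 to compound 4, set beside the measured 12-fold higher number from compound 2 to compound 1 (1.08 log units; beyond the scatter). This expectation rests on two points: the measured pair lost activity with iodo in place of ethynyl, and compound 3 itself already sits at the limit, > 20000 nM. A further loss from a limit can only remain a limit. Compound 4 is therefore estimated at 60000 nM, with a range from 20000 nM to 300000 nM, and most probably the assay will again report only a limit for compound 4.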

Compound 4, half-maximal inhibitory concentration: 6310 nM
The estimate for compound 4 lay 9.5-fold (0.98 log units) above the measured number; measured number outside the range, below it.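

In this assay, iodo in place of ethynyl on an aromatic carbon gives an at least 3.1-fold lower number from compound 3 to compound 4 (0.50 log units; beyond the scatter), so the loss seen on the core of compound 2 does not carry over to the core of compound 3: the same change on two cores in this assay, a 12-fold higher number (1.08 log units; beyond the scatter) from compound 2 to compound 1 and an at least 3.1-fold lower number (0.50 log units; beyond the scatter) from compound 3 to compound 4, at least 37-fold (1.57 log units) apart, beyond the scatter of two such steps. The step from compound 3 is a minimum and its full size cannot be read, as the value for compound 3 is a limit and not a number: the limit of > 20000 nM in this assay, at which 1 of the 4 values shown sits. The difference between the two cores is not broken down, so these results do not show which part of it goes with the reversal, and with one pair on each core they set no rule for any other core.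

The compounds shown leave open how other groups on this aromatic carbon, such as a nitrile, a bromo group or a longer alkynyl chain, would compare with iodo and ethynyl on either core. Also open, going by these compounds, is how a core carrying an amine but no methyl group would respond to the same change.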